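Nitro in Place of Bromo: From Compound 2 to Compound 3

A few compounds are considered here, and "the series" means these few. Any claim that something is new, unique, unknown or untested is made for them only; others in the source may bear on it.

Of the compounds shown here, two carry numbers so far. Compound 1 `N#CCC1=C(C#N)CC(c2ccc([N+](=O)[O-])cc2)=C(CC(=O)c2ccc(Br)cc2)O1` gives 2800 nM in a functional assay on SF-268 cells (Homo sapiens) for inhibition, read by sulforhodamine B assay, with a stated time of 48 h; a lower number here means a stronger inhibitor of growth, a higher number a weaker inhibitor of growth. Compound 2 `N#CCC1=NN=C(c2ccc(Br)cc2)C(CC(=O)c2ccc(Br)cc2)O1` gives 16900 nM in this assay, the highest of the two numbers; its nearest neighbour is compound 1, whose number sits lower by a gap beyond the scatter. For the measured compounds named here, the two measured compounds differ in more than one place, so their values show only that compound 2 is the weaker grower inhibitor of the pair.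

Compound 3 `N#CCC1=NN=C(c2ccc([N+](=O)[O-])cc2)C(CC(=O)c2ccc(Br)cc2)O1` awaits measurement. It differs from compound 2 by nitro in place of bromo on an aromatic carbon, on an aromatic carbon of a six-membered aromatic ring of carbon only, para to a large group; one bond further out, this reads 4-bromophenyl to 4-nitrophenyl. Going by the values given here, no measured step of this kind exists here, so the step of a 1.4-fold lower number from compound 2 to compound 3 (0.15 log units; within the scatter) is expected to stay modest, leaning toward a lower number. Compound 3 is estimated at 12000 nM, within 4000 nM to 35000 nM.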

Compound 3, concentration for 50% growth inhibition: 16500 nM
The estimate for compound 3 lay 1.4-fold (0.14 log units) below the measured number; low and high end bracket the measured number.
By their numbers in this assay, from the lowest: compound 1; then compounds 3 and 2 (each within the scatter of the next).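

In this assay, for the compounds shown here, the change from 4-bromophenyl to 4-nitrophenyl gives a 1.0-fold lower number from compound 2 to compound 3 (0.01 log units; within the scatter), the first step here in which only one place differs. On an aromatic carbon of a six-membered aromatic ring of carbon only, para to a large group, nitro with its 3 heavy atoms and 2 hydrogen-bond acceptors therefore cannot be told apart from a single bromine in growth inhibition on this core. No measurement available here bears on why the two groups read alike.

The compounds shown leave open whether an amine or a carboxylic acid at this same place would also stay within the scatter of compound 2. They also leave open whether nitro and bromo would read alike on the core of compound 1, since no bromo partner of that compound is shown.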